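The source may hold more compounds than are shown below. What is called first, only, known or untested is meant among the compounds shown, and "the series" means these compounds.

Measured so far in an ADME assay on L02 cells (Homo sapiens) for cytotoxicity, read by MTT assay, with a stated time of 48 h; on this read-out lower numbers stand for stronger inhibition and higher numbers for weaker inhibition:
compound 1 `O=C1CCC(=O)N1C[C@H]1CN(c2ccc(-n3cc(-c4ccccn4)cn3)c(F)c2)C(=O)O1`: > 400 ug/mL
compound 2 `COC[C@H]1CN(c2ccc(-n3cc(-c4ccccn4)cn3)c(F)c2)C(=O)O1`: > 400 ug/mL
compound 3 `O=C1O[C@@H](Cn2ccnn2)CN1c1ccc(-n2cc(-c3ccccn3)cn2)c(F)c1`: 49 ug/mL

Compound 1 and compound 2 carry no exact number: each reports (the limit of > 400 ug/mL in this assay, at which 2 of the 3 values shown sit). Going by the values given here, compound 3 therefore holds the only true number of the three, and it is the lowest reading, meaning the strongest inhibition in this assay.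

The next compound, compound 4 `CN(C)S(=O)(=O)NC[C@H]1CN(c2ccc(-n3cc(-c4ccccn4)cn3)c(F)c2)C(=O)O1`, has (dimethylsulfamoyl)amino in place of 1H-1,2,3-triazol-1-yl on a saturated chain carbon bound to a saturated ring carbon.

Among the compounds with values here, two measured steps bear on this change, since both swap another group for the same 1H-1,2,3-triazol-1-yl at that place. One is an at least 8.1-fold lower number from compound 1 to compound 3 (0.91 log units; beyond the scatter), and the other is an at least 8.1-fold lower number from compound 2 to compound 3 (0.91 log units; beyond the scatter). Run in reverse, they suggest that removing this group from compound 3 could raise the number by a modest step or more. Neither step tests the (dimethylsulfamoyl)amino group itself, so the size remains uncertain, and compound 4 may also reach the limit.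

The expected change is a 4.1-fold higher number from compound 3 to compound 4 (0.61 log units; beyond the scatter), towards weaker inhibition. For compound 4 the estimated value is 200 ug/mL, with an expected range from 70 ug/mL to 600 ug/mL.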

Compound 4, half-maximal inhibitory concentration: 158 ug/mL
Estimate against measurement, compound 4: 1.3-fold (0.10 log units) above; low and high end bracket the measured number.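

Going by these compounds alone, until now the only exact number at this place, on a saturated chain carbon bound to a saturated ring carbon, belonged to the 1H-1,2,3-triazol-1-yl group; compound 4 adds a second exact reading in this assay, and the change to (dimethylsulfamoyl)amino is a 3.2-fold higher number from compound 3 to compound 4 (0.51 log units; beyond the scatter). The new group also reads lower than the other two, with an at least 2.5-fold lower number from compound 2 to compound 4 (0.40 log units; beyond the scatter) and an at least 2.5-fold lower number from compound 1 to compound 4 (0.40 log units; beyond the scatter), and the compounds at this place now fall on three levels rather than splitting into the 1H-1,2,3-triazol-1-yl group and all the rest. Those last two steps are bounded on one side only, since compound 1 and compound 2 rest on a limit and not on a number: the limit of > 400 ug/mL in this assay, at which 2 of the 4 values shown sit.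

Compound 4 differs from compound 3 in its ring, its hydrogen-bond donor and its heavy-atom count all at once, and these two compounds cannot show which of these differences goes with the higher number. Going by these compounds, a simple amine, a carboxylic acid or a longer chain at this place could help separate them, and the true readings of compound 1 and compound 2 remain unknown.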